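This account rests on a few compounds, and the source may have more. Where it says the series, first, only, none or still open, it means among the compounds named here.

For the measured compounds named here, in a functional assay on DU-145 cells (Homo sapiens) for inhibition (on this read-out lower numbers stand for stronger inhibition and higher numbers for weaker inhibition), compound 1 `CCOc1ccc(Br)cc1-c1cc(Nc2ccc(C#N)cc2)nc(N)n1` gives 400 nM, the only actual number so far. Compound 2 `CCOc1ccc(Cl)cc1-c1cc(Nc2ccc(CCCO)cc2)nc(N)n1` reads > 1000 nM, which is a limit of the assay and not a number. Compound 3 `CCOc1ccc(Cl)cc1-c1cc(Nc2cccc([N+](=O)[O-])c2)nc(N)n1` reads > 1000 nM, again a limit and not a number.

Compound 4 `CCOc1ccc(Br)cc1-c1cc(Nc2ccc(Cl)cc2)nc(N)n1` is the next compound to be read in this assay. It keeps the core of compound 1 and carries chloro in place of cyano on an aromatic carbon. This is chloro in place of cyano on an aromatic carbon, para to a large group, so 4-cyanophenyl becomes 4-chlorophenyl.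

Going by the values given here, no measured pair isolates this change, so the expectation is anchored only on compound 1 at 400 nM. A modest move toward weaker inhibition is expected, perhaps not beyond the usual scatter, and a reading that reaches the assay limit cannot be excluded. The expected change is a 1.3-fold higher number from compound 1 to compound 4 (0.10 log units; within the scatter). For compound 4 the estimated value is 500 nM, with an expected range of 150 nM to 1500 nM.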

Compound 4, half-maximal inhibitory concentration: 80 nM
Beside the measured number, compound 4's estimate is 6.3-fold (0.80 log units) above it, outside the stated range (below it).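

In this assay, for the compounds shown here, the change from 4-cyanophenyl to 4-chlorophenyl gives a 5.0-fold lower number from compound 1 to compound 4 (0.70 log units; beyond the scatter), the first step that differs in one place. This position therefore responds to the group it carries, and the nitrile is not required there for inhibition, since the chloro, with no hydrogen-bond acceptor counted, gives the lower number. Steps to compounds 2 and 3 cannot be read, as both differ from compound 1 and compound 4 in more than one place and neither gives a number: the limit of > 1000 nM in this assay, at which 2 of the 4 values shown sit.

One step does not show which feature of the exchange accounts for the difference. Also open, going by these compounds, is how fluoro, methoxy, an amine or a carboxylic acid would read at this position, and whether the same step holds with chloro in place of the bromo on the shared core.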